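Chloro on the benzyl group of compound 3

This account rests on a few compounds, and the source may have more. Where it says the series, first, only, none or still open, it means among the compounds named here.

Compound 3 `O=S(=O)(NCCCNCc1ccccc1)c1cc(C(F)(F)F)cc(C(F)(F)F)c1` stands second highest of the three numbers in a functional assay on HPAC cells (Homo sapiens) for inhibition, read by MTT assay, with a stated time of 72 h (a higher number here means a weaker inhibitor of growth, a lower number a stronger inhibitor of growth), where compound 3 gives 3200 nM. Compound 1 `O=S(=O)(NCCCCNCc1ccc(Br)cc1)c1cc(C(F)(F)F)cc(C(F)(F)F)c1` gives 2000 nM, and a 1.6-fold higher number from compound 1 to compound 3 (0.20 log units; within the scatter). Compound 2 `CN(CCCNS(=O)(=O)c1cc(C(F)(F)F)cc(C(F)(F)F)c1)Cc1ccccc1` gives 30000 nM, and a 9.4-fold lower number from compound 2 to compound 3 (0.97 log units; beyond the scatter). Compound 4 `O=S(=O)(NCCCNCc1ccc(Cl)cc1)c1cc(C(F)(F)F)cc(C(F)(F)F)c1` differs from compound 3 by chloro in place of hydrogen on an aromatic carbon, with the group entering on an aromatic carbon of a six-membered aromatic ring of carbon only, para to a large group. For the measured compounds named here, of the measured steps only the one from compound 1 to compound 3 bears on a halogen on that ring, and it lies within the scatter. Compound 4 is therefore expected to sit close to compound 3, a step of a 1.3-fold lower number from compound 3 to compound 4 (0.11 log units; within the scatter). The estimate for compound 4 is 2500 nM, within 1000 nM to 6000 nM.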

Compound 4, concentration for 50% growth inhibition: 2800 nM
Compound 4: the middle estimate sits 1.1-fold (0.05 log units) below what was measured, and the stated range covers the measured number.
By their numbers in this assay, from the lowest: compounds 1, 4 and 3 (each within the scatter of the next); then compound 2.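

In this assay the first direct test of a halogen at this ring position, without a second change elsewhere, does not separate 4-chlorobenzyl from benzyl (a 1.1-fold lower number from compound 3 to compound 4 (0.06 log units; within the scatter)). The 4-chlorobenzyl compound also lies within the scatter of the 4-bromobenzyl compound with its different chain (a 1.4-fold higher number from compound 1 to compound 4 (0.15 log units; within the scatter)), while the gap to the methylated amine holds with chloro present (an 11-fold lower number from compound 2 to compound 4 (1.03 log units; beyond the scatter)). No measurement shown accounts for these numbers. Open, on these data alone, is whether methoxy, nitrile or a carboxylic acid at this ring position would move the number beyond the scatter. Also open, as far as these compounds go, is how 4-chlorobenzyl behaves on a longer chain.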